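From pyridin-3-yl to pyridin-4-yl on compound 2

The source may report more compounds than this note shows. Statements on the series, on what has been measured and on what is new or still open speak of the compounds shown alone.

Measured in a functional assay on QGY-7703 cells (Homo sapiens) for cytotoxicity, read by MTT assay, with a stated time of 24 h; on this read-out lower numbers stand for stronger inhibition and higher numbers for weaker inhibition:
- Compound 1 `COc1cc(/C=C2\CN(C)C/C(=C\c3cccnc3)C2=O)cc(OC)c1OC`: 4300 nM
- Compound 2 `CN1C/C(=C\c2cccnc2)C(=O)/C(=C/c2ccc(F)cc2Br)C1`: 2610 nM
- Compound 3 `CN1C/C(=C\c2ccc(C#N)cc2)C(=O)/C(=C/c2cccnc2)C1`: > 20000 nM, a limit of the assay

Compound 1 at 4300 nM and compound 2 at 2610 nM lie within the usual scatter of each other, so neither can be ranked over the other. For compound 3 the result is only a limit, > 20000 nM, and not a number.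

The account now turns to compound 4 `CN1C/C(=C\c2ccncc2)C(=O)/C(=C/c2ccc(F)cc2Br)C1`, an isomer of compound 2. The difference is pyridin-4-yl in place of pyridin-3-yl on a double-bonded chain carbon bound to a double-bonded ring carbon.

Within the data shown here, only one measured step bears on this, and only indirectly. It is an at least 7.6-fold higher number from compound 2 to compound 3 (0.88 log units; beyond the scatter), a change beyond the scatter with 4-cyanophenyl in place of 2-bromo-4-fluorophenyl. Among the measured compounds shown here, that step leaves the pyridin-3-yl untouched, and no measured pair exchanges the pyridine itself. The 2-bromo-4-fluorophenyl of compound 2 stays in compound 4, so no large shift is expected in this assay, though the uncertainty is wide.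

The estimated change is a 1.1-fold higher number from compound 2 to compound 4 (0.06 log units; within the scatter), which is expected to stay within the scatter. For compound 4 the expected value is 3000 nM, with an estimated range of 1000 nM to 9000 nM.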

Compound 4, half-maximal inhibitory concentration: 6900 nM
The estimate for compound 4 lay 2.3-fold (0.36 log units) below the measured number, within the range that was stated.
By their numbers in this assay, from the lowest: compounds 2, 1 and 4 (each within the scatter of the next, the first and the last beyond it). At a limit, above all of these: compound 3.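

In this assay, among these compounds, the exchange of pyridin-3-yl for pyridin-4-yl on a double-bonded chain carbon bound to a double-bonded ring carbon gives a 2.6-fold higher number from compound 2 to compound 4 (0.42 log units; beyond the scatter) and this is the first measured step in which the pyridine itself changes while the 2-bromo-4-fluorophenyl stays in place. The two groups have the same atoms and the same counts of heavy atoms, hydrogen-bond donors and hydrogen-bond acceptors, so the step beyond the scatter comes with a difference in how those atoms are joined and not in which atoms are present. The compounds shown offer no measurement that accounts for this shift.

As far as these compounds go, it remains open whether pyridin-2-yl, or a phenyl carrying an amine or a carboxylic acid, would give a number in this place nearer to that of compound 2 or to that of compound 4. From the compounds shown here alone, it also remains open whether the same exchange of pyridines would give a step of similar size when the 2-bromo-4-fluorophenyl gives way to the other aromatic group of compound 1.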